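Adding one bromo group to a compound at the limit

The compounds below may be only part of what the source reports. "The series", "measured", "known", "first", "only" and "open" are said of these compounds alone.

Compound 1 `O=C(Nc1cccc(Cl)c1)c1cc(Br)cc(Br)c1O`, compound 2 `O=C(Nc1cccc(Cl)c1)c1ccccc1O` and compound 3 `COc1ccccc1C(=O)Nc1cccc(Cl)c1` share one core and were each tested in an assay on isolated protein for inhibition of thiosulfate sulfurtransferase (Homo sapiens), with a stated time of 60 min, in the absence of a further agent; on this read-out lower numbers stand for stronger inhibition and higher numbers for weaker inhibition. For compound 1 the read-out is only a limit, > 100000 nM. Compound 2 likewise returns only a limit, > 100000 nM, so its standing on the numbers reaches no further than that. Compound 3 also sits at a limit, > 100000 nM. The step that the two limits leave unreadable from compound 2 to compound 3 therefore has no readable size. Compound 4 `O=C(Nc1cccc(Cl)c1)c1cc(Br)ccc1O` differs from compound 2 by bromo in place of hydrogen on an aromatic carbon, the entering bromine standing para to the hydroxy group and meta to a large group. For the measured compounds named here, because the limit of > 100000 nM in this assay, at which 3 of the 3 values shown sit, no measured step supplies a number to build on, and compound 1, which carries two bromo groups, also sits there. Compound 4 is therefore expected to show a step that the limit leaves unreadable from compound 2 to compound 4, none beyond the scatter, with an estimate of 150000 nM between 50000 nM and 500000 nM.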

Compound 4, half-maximal inhibitory concentration: > 100000 nM
Compound 4: only a limit was reported; the forecaster's own chance of this, stated with the estimate: 85%; the middle value lies beyond the limit too.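

For the compounds shown here, compound 4 returns only a limit, > 100000 nM, so no step linking it to compound 2 or compound 1 can be read. The compounds shown leave open which change to the shared core, if any, would give a readable value: the limit of > 100000 nM in this assay, at which 4 of the 4 values shown sit.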